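Dropping the Carbamoylamino Linker from Compound 3

A few compounds are considered here, and "the series" means these few. Any claim that something is new, unique, unknown or untested is made for them only; others in the source may bear on it.

Going by the values given here, compound 3 `COc1cc(NC(C)CCCNC(=O)NNC(=O)Nc2ccc(Cl)cc2)c2ncccc2c1` gives 180 nM in a functional assay on MCF7 cells (Homo sapiens) for inhibition, read by MTT assay, with a stated time of 72 h (a higher number here means a weaker inhibitor, a lower number a stronger inhibitor), which is second highest of the three numbers measured so far: its nearest neighbour is compound 1 `COc1cc(NC(C)CCCNC(=O)NNC(=O)Nc2cccc(F)c2)c2ncccc2c1` with 150 nM, while compound 2 `COc1cc(NC(C)CCCNC(=O)Nc2ccc(O)cc2)c2ncccc2c1` with 5200 nM stands far away. Compound 4 `COc1cc(NC(C)CCCNC(=O)Nc2ccc(Cl)cc2)c2ncccc2c1` has not yet been measured. It differs from compound 3 in one place: 4-chlorophenyl in place of ((4-chlorophenyl)carbamoyl)amino on an amide-type nitrogen.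

Among the compounds with values here, two measured steps bear on this change. The step of a 29-fold lower number from compound 2 to compound 3 (1.46 log units; beyond the scatter) shows what the carbamoylamino group adds, and the step of a 35-fold higher number from compound 1 to compound 2 (1.54 log units; beyond the scatter) shows the same change in the other direction, mixed with a change of the attached aryl group. By contrast, the step of a 1.2-fold higher number from compound 1 to compound 3 (0.08 log units; within the scatter) shows that swapping one halogenated aryl group for another hardly matters. Removing the carbamoylamino group is therefore expected to cost a large step in this assay, as the estimated 25-fold higher number from compound 3 to compound 4 (1.40 log units; beyond the scatter) states. Compound 4 is thus expected to give about 4500 nM, with a likely range from 1500 nM to 14000 nM.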

Compound 4, half-maximal inhibitory concentration: 12000 nM
Estimate against measurement, compound 4: 2.7-fold (0.43 log units) below, and the stated range covers the measured number.
By their numbers in this assay, from the lowest: compounds 1 and 3 (each within the scatter of the next); then compound 2; then compound 4.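

In this assay, removing the carbamoylamino group can now be read on its own, with the 4-chlorophenyl group kept in place: the step is a 67-fold higher number from compound 3 to compound 4 (1.82 log units; beyond the scatter) and confirms that this group on the amide-type nitrogen matters greatly. The step of an 80-fold higher number from compound 1 to compound 4 (1.90 log units; beyond the scatter) is similarly large, though it also changes the halogenated aryl group, while without the carbamoylamino group the step of a 2.3-fold higher number from compound 2 to compound 4 (0.36 log units; beyond the scatter) is only modest, for chloro in place of hydroxy on an aromatic carbon. Nothing available explains why the carbamoylamino group has so large an effect.

On these data alone, it remains open whether a sulfonyl group or a longer carbon chain in this same place on the amide-type nitrogen could take over the role of the carbamoylamino group. As far as these compounds go, how an amine on the phenyl ring would compare with chloro and hydroxy also remains open.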